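The compounds below may be only part of what the source reports. "The series", "measured", "known", "first", "only" and "open" are said of these compounds alone.

In a functional assay on HCT-116 cells (Homo sapiens) for inhibition, read by MTT assay, with a stated time of 72 h (on this read-out higher numbers stand for weaker inhibition of growth and lower numbers for stronger inhibition of growth), compound 1 `CCOC(=O)/C=C/c1ccncc1-c1ccc2ccccc2c1` gives 910 nM. Compound 2 `COC1CN(C(=O)/C=C/c2ccncc2-c2ccc3ccccc3c2)C1` gives > 30000 nM, which is a limit of the assay and not a number. Compound 3 `CC(C)[C@@H](NC(=O)/C=C/c1ccncc1-c1ccc2ccccc2c1)C(=O)O` stands at "not determined" (no result reported), so it offers no number to start from. Compound 4 `NC(=O)/C=C/c1ccncc1-c1ccc2ccccc2c1` differs from it by hydrogen in place of 1-carboxy-2-methylpropyl on an amide-type nitrogen. Among the compounds with values here, no step from compound 3 can therefore be sized. Within the data shown here, the one measured step that bears on this is large and beyond the scatter, an at least 32-fold higher number from compound 1 to compound 2 (1.51 log units; beyond the scatter), with 3-methoxyazetidin-1-yl in place of ethoxy on a carbonyl carbon. On that step, compound 4, which also has nitrogen on that carbon, is expected to show a clearly higher number than compound 1 in this assay, meaning weaker inhibition. For compound 4 the estimated value is 6000 nM, with an expected range from 1000 nM to 30000 nM.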

Compound 4, concentration for 50% growth inhibition: 12100 nM
For compound 4 the middle estimate is 2.0-fold (0.30 log units) below the measured one, and the stated range covers the measured number.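

Within the data shown here, compound 4 gives the first measured number with nitrogen on this carbonyl carbon, so the loss on replacing ethoxy with amino can now be sized (the change gives a 13-fold higher number from compound 1 to compound 4 (1.12 log units; beyond the scatter)). Amino in place of 3-methoxyazetidin-1-yl gives a measurable growth inhibition in this assay (the change gives an at least 2.4-fold lower number from compound 2 to compound 4 (0.39 log units; beyond the scatter)). On these data alone, the size of that second step stays open-ended, since compound 2 stands at a limit and not a number: the limit of > 30000 nM in this assay, at which 1 of the 4 values shown sits. Among these compounds, no step from compound 3 can be read, as it has no result. As far as these compounds go, whether a methylamino group or a carboxylic acid on this carbonyl carbon would come closer to ethoxy stays open.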